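The source may report more compounds than this note shows. Statements on the series, on what has been measured and on what is new or still open speak of the compounds shown alone.

- Compound 1 `O=c1ccn([C@@H]2S[C@H](CO)[C@H]2CO)c(=O)[nH]1`: 8500 nM
- Compound 2 `Cc1cn([C@H]2S[C@@H](CO)[C@@H]2CO)c(=O)[nH]c1=O`: > 100000 nM

Both compounds were tested in a functional assay on PBMC cells (Homo sapiens) for cytotoxicity; a lower number here means a stronger inhibitor, a higher number a weaker inhibitor. Compound 2 reads > 100000 nM, which is a limit of the assay and not a number. It therefore stands at the limit of > 100000 nM in this assay, at which 1 of the 2 values shown sits. Compound 1, by contrast, returned a real number, 8500 nM.

The next compound to be examined in this assay is compound 3 `O=c1ccn([C@H]2S[C@@H](CO)[C@@H]2CO)c(=O)[nH]1`. It differs from compound 2 in a single place: hydrogen in place of methyl on an aromatic carbon. In words, hydrogen stands in place of methyl on an aromatic carbon. Among the compounds with values here, no measured pair in this small set isolates that change, so its size has to be judged rather than read off.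

Compound 1 at 8500 nM shows that a measurable value is possible in this set, so a move towards stronger inhibition is expected, though only a moderate one. The assay may well report a limit again. The expected change is an at least 2.5-fold lower number from compound 2 to compound 3 (0.39 log units; beyond the scatter). Compound 3 is estimated at 40000 nM, with an expected range of 8000 nM to 100000 nM.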

Compound 3, half-maximal inhibitory concentration: > 100000 nM
Compound 3 was reported as a limit (the forecaster's own chance of this, stated with the estimate: 50%); middle value at least 2.5-fold (0.39 log units) from the limit.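

In this assay compound 3 reads > 100000 nM, which is a limit and not a number, so hydrogen in place of methyl on an aromatic carbon does not yield a measurable value in this configuration, and the step from compound 2 cannot be read: the limit of > 100000 nM in this assay, at which 2 of the 3 values shown sit. The measurable value is tied instead to configuration, with an at least 11-fold higher number from compound 1 to compound 3 (1.07 log units; beyond the scatter). That step comes with no change in atoms or bonds, so it rests on configuration alone: the fact that compounds 1 and 3 differ only in the configuration as drawn.

The compounds shown leave open what methyl on that aromatic carbon would do in the configuration of compound 1, where a real number can be read, since the only methyl compound here, compound 2, has the configuration of compound 3. Going by these compounds, how an ethyl group or a bromine atom at the same place would read in either configuration also stays open.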